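Adding a Methoxy Group to an Inactive Diaryl Ether

The compounds below may be only part of what the source reports. "The series", "measured", "known", "first", "only" and "open" are said of these compounds alone.

Compound 1, `CCOC(=O)c1ccc(Oc2ccc(N(C)C)cc2)cc1`: > 20000 nM
Compound 2, `COC(=O)c1ccc(Oc2ccc(OC)cc2)c([N+](=O)[O-])c1`: > 20000 nM

In a functional assay on HL-60 cells (Homo sapiens) for antiproliferative activity (on this read-out lower numbers stand for stronger inhibition and higher numbers for weaker inhibition), both measured compounds gave only limits rather than numbers. Compound 1 reached the limit > 20000 nM. Compound 2 likewise reached the limit > 20000 nM. Compound 2 therefore stands at the limit of > 20000 nM in this assay, at which 2 of the 2 values shown sit, so the values shown give no ranking among them and no guide to how far below that limit either compound might lie.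

Compound 3, `COC(=O)c1ccc(Oc2ccc(OC)c(OC)c2)c([N+](=O)[O-])c1`, differs from compound 2 in one place: methoxy in place of hydrogen on an aromatic carbon. Among the compounds with values here, no step between measured compounds has been determined, so there is nothing to show how large a change of this kind can be. The expectation is a step of no more than the usual scatter, in no particular direction. Compound 3 is expected to give about 25000 nM, between 8000 nM and 80000 nM. The expected step that the limit leaves unreadable from compound 2 to compound 3 is thus none beyond the scatter, and the readout for compound 3 will most likely again be a limit.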

Compound 3, half-maximal inhibitory concentration: > 20000 nM
Compound 3: only a limit was reported; the forecaster's own chance of this, stated with the estimate: 80%; the middle value does not contradict the limit.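

Within the data shown here, compound 2 and compound 3 both gave only limits, so no step between them can be read: the limit of > 20000 nM in this assay, at which 3 of the 3 values shown sit. Left open is how strongly either compound acts in this assay and whether methoxy in place of hydrogen on an aromatic carbon changes that at all.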